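Adding a Second Methoxy Group: Measured and Expected Effects

The source may hold more compounds than are shown below. What is called first, only, known or untested is meant among the compounds shown, and "the series" means these compounds.

Measured in a functional assay on MCF7 cells (Homo sapiens) for cytotoxicity, read by MTT assay, with a stated time of 72 h; on this read-out higher numbers stand for weaker inhibition and lower numbers for stronger inhibition:
compound 1 `COc1ccc(/C=C2\S/C(=N\c3csc(-c4ccc(Cl)cc4)c3)NC2=O)cc1` gives 1000 nM.
compound 2 `COc1ccc(/C=C2\S/C(=N\c3csc(-c4ccc(Cl)cc4)c3)NC2=O)cc1OC` gives 7600 nM.
compound 3 `COc1cccc(N2C(=O)CS/C2=N\c2csc(-c3ccc(Cl)cc3)c2)c1` gives only a limit of the assay, > 50000 nM.

Compounds 1 and 2 share a core, and the change between them is methoxy in place of hydrogen on an aromatic carbon. In this assay it gave a 7.6-fold higher number from compound 1 to compound 2 (0.88 log units; beyond the scatter). Compound 3 has a different core; the difference between the two cores is not broken down here. Compound 4 `COc1ccc(N2C(=O)CS/C2=N\c2csc(-c3ccc(Cl)cc3)c2)cc1OC` is unmeasured and differs from compound 3 by methoxy in place of hydrogen on an aromatic carbon. This is the same kind of change as from compound 1 to compound 2, though in compound 2 the entering group sits meta to a large group and in compound 4 para to a large group. Since compound 3 already sits at the limit of > 50000 nM in this assay, at which 1 of the 3 values shown sits, and the earlier step weakened inhibition, compound 4 is expected to stay at or beyond that limit, an estimated step that the limit leaves unreadable from compound 3 to compound 4. The estimate for compound 4 in this assay is 150000 nM, between 50000 nM and 500000 nM.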

Compound 4, half-maximal inhibitory concentration: 18700 nM
For compound 4 the middle estimate is 8.0-fold (0.90 log units) above the measured one, outside the stated range (below it).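

In this assay, the added methoxy gave an at least 2.6-fold lower number from compound 3 to compound 4 (0.42 log units; beyond the scatter). The same change thus moved the read-out in opposite directions on the two cores, so its effect did not carry from one core to the other: the same change on two cores in this assay, a 7.6-fold higher number (0.88 log units; beyond the scatter) from compound 1 to compound 2 and an at least 2.6-fold lower number (0.42 log units; beyond the scatter) from compound 3 to compound 4, at least 20-fold (1.30 log units) apart, beyond the scatter of two such steps

Compound 3 gives > 50000 nM, a limit of the assay, and a single pair on each core does not show whether the core itself or the place of the entering group, para to a large group in compound 4, sets the direction.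

The compounds shown leave open how a hydroxyl, an ethoxy or an amine at the same place would behave on either core. They also leave open whether a second methoxy at another place on the ring would follow the same course.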